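This account rests on a few compounds, and the source may have more. Where it says the series, first, only, none or still open, it means among the compounds named here.

Measured compounds in a functional assay on MCF7 cells (Homo sapiens) for antiproliferative activity, read by MTT assay, with a stated time of 72 h; a lower number here means a stronger inhibitor, a higher number a weaker inhibitor:
compound 1 `O=C(N/N=C/c1ccccc1)Nc1ccc(Oc2ccnc3[nH]ccc23)cc1` gives 1510 nM
compound 2 `O=C(N/N=C/c1ccc(O)cc1)Nc1ccc(Oc2ccnc3[nH]ccc23)cc1` gives 5800 nM

Among the measured compounds shown here, compound 2 gives the highest number of the two in this assay; its only neighbour is compound 1, and the step of a 3.8-fold higher number from compound 1 to compound 2 (0.58 log units; beyond the scatter) separates them. Compound 3 `CN(C)CCCn1cccc1/C=N/NC(=O)Nc1ccc(Oc2ccnc3[nH]ccc23)cc1` has not yet been measured. It differs from compound 2 in one place: 1-(3-(dimethylamino)propyl)-1H-pyrrol-2-yl in place of 4-hydroxyphenyl on a carbon with a double bond to nitrogen. For the measured compounds named here, no measured step covers this exchange. Going by the values given here, the one step on record, a 3.8-fold higher number from compound 1 to compound 2 (0.58 log units; beyond the scatter), concerns the hydroxy group that compound 3 loses together with the whole 4-hydroxyphenyl group, so it offers only a weak hint that removing that group may bring the number back down. The expectation is therefore a number nearer that of compound 1 than of compound 2, with a wide range. Compound 3 is estimated at 2000 nM (range 500 nM to 10000 nM), an expected step of a 2.9-fold lower number from compound 2 to compound 3 (0.46 log units; beyond the scatter).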

Compound 3, half-maximal inhibitory concentration: 9140 nM
Compound 3: middle estimate off by 4.6-fold (0.66 log units), on the low side, within the range that was stated.
By their numbers in this assay, from the lowest: compound 1; then compounds 2 and 3 (each within the scatter of the next).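

In this assay, the exchange of 4-hydroxyphenyl for 1-(3-(dimethylamino)propyl)-1H-pyrrol-2-yl, a 1.6-fold higher number from compound 2 to compound 3 (0.20 log units; within the scatter), gives no real separation between the two groups on this carbon, even though the entering group is larger and carries a chain. Measured against the unsubstituted phenyl group, the same group gives a 6.1-fold higher number from compound 1 to compound 3 (0.78 log units; beyond the scatter), so among these three compounds the plain phenyl of compound 1 still gives the lowest number. Nothing shown here explains these differences.

Compound 3 changes the ring and adds the chain in a single step, so it remains open which of the two accounts for its higher number than compound 1; a plain 1H-pyrrol-2-yl group would separate them. Also open, on these data alone, is whether any group on this carbon can beat phenyl, for example a phenyl ring bearing methoxy or fluorine.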